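Swapping Thiophene for Furan: What the Numbers Suggest

This account rests on a few compounds, and the source may have more. Where it says the series, first, only, none or still open, it means among the compounds named here.

Measured in a functional assay on HCT-15 cells (Homo sapiens) for cytotoxicity, read by CCK-8 assay; on this read-out lower numbers stand for stronger inhibition and higher numbers for weaker inhibition:
compound 1, `Oc1ccc(-c2cc(-c3ccsc3)cc(-c3ccccc3O)n2)cc1` — > 50000 nM
compound 2, `Oc1ccc(-c2cc(-c3ccsc3)cc(-c3cccc(O)c3)n2)cc1` — 1180 nM
compound 3, `Oc1ccc(-c2cc(-c3ccsc3)cc(-c3ccc(O)cc3)n2)cc1` — 1040 nM

In this assay compound 1 gives > 50000 nM, which is a limit of the assay (the limit of > 50000 nM in this assay, at which 1 of the 3 values shown sits). Compound 2 gives 1180 nM and compound 3 gives 1040 nM in this assay; these two numbers lie within the scatter of each other (a 1.1-fold lower number from compound 2 to compound 3 (0.05 log units; within the scatter)), so neither can be set above the other. The step from compound 1 to compound 2 was large (an at least 42-fold lower number from compound 1 to compound 2 (1.62 log units; beyond the scatter)), as was the step from compound 1 to compound 3 (an at least 48-fold lower number from compound 1 to compound 3 (1.68 log units; beyond the scatter)).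

Compound 4, `Oc1ccc(-c2cc(-c3ccoc3)cc(-c3ccc(O)cc3)n2)cc1`, differs from compound 3 by furan-3-yl in place of thiophen-3-yl on an aromatic carbon. Among the compounds with values here, all three measured steps concern the hydroxyphenyl group; none touches the five-membered ring, so no measured step bears directly on this change. The expectation for this assay is therefore no step beyond the scatter. Compound 4 is estimated at 1200 nM, with a range from 450 nM to 3500 nM. The step this estimate implies is expected to be a 1.2-fold higher number from compound 3 to compound 4 (0.06 log units; within the scatter).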

Compound 4, half-maximal inhibitory concentration: 1530 nM
Compound 4: middle estimate off by 1.3-fold (0.11 log units), on the low side; the range from low to high includes it.
By their numbers in this assay, from the lowest: compounds 3, 2 and 4 (each within the scatter of the next). At a limit, above all of these: compound 1.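

Compound 4 is the only compound shown in which the five-membered ring differs; all the others vary the hydroxyphenyl group. At the position opposite the ring nitrogen, furan-3-yl in place of thiophen-3-yl gives a 1.5-fold higher number from compound 3 to compound 4 (0.17 log units; within the scatter), so this assay does not separate these two rings, and exchanging the sulfur of the ring for oxygen leaves the number within the usual scatter. The evidence at hand has no information that bears on this result.

Going by these compounds, whether this position would accept something other than a five-membered aromatic ring, such as an amine, a carboxylic acid or a longer alkyl chain, remains open. On these data alone, it is also open whether furan-3-yl would read the same alongside the 3-hydroxyphenyl group of compound 2 or the 2-hydroxyphenyl group of compound 1.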